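From benzyl to 3-methylphenyl on an aromatic nitrogen

The compounds below may be only part of what the source reports. "The series", "measured", "known", "first", "only" and "open" are said of these compounds alone.

Compound 1 `COc1cc(-c2nccn2C)cc(OC)c1OC`: > 100000 nM, a limit
Compound 2 `COc1cc(-c2nccn2Cc2ccccc2)cc(OC)c1OC`: > 100000 nM, a limit

Both compounds were tested in a functional assay on HCT-15 cells (Homo sapiens) for antiproliferative activity, read by MTT assay, with a stated time of 72 h (on this read-out higher numbers stand for weaker inhibition and lower numbers for stronger inhibition), and neither gave a number. In this assay compound 2 gives > 100000 nM, which is a limit of the assay. It therefore stands at the limit of > 100000 nM in this assay, at which 2 of the 2 values shown sit.

Compound 3 `COc1cc(-c2nccn2-c2cccc(C)c2)cc(OC)c1OC` has not yet been measured. It differs from compound 2 as follows: 3-methylphenyl in place of benzyl on an aromatic nitrogen. In words, 3-methylphenyl stands in place of benzyl on an aromatic nitrogen.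

Within the data shown here, the one measured step that bears on this is a step that the two limits leave unreadable from compound 1 to compound 2. It offers no size to carry over, so in this assay only a modest move towards stronger inhibition is expected, and compound 3 may also return only a limit.

The expected change is an at least 1.6-fold lower number from compound 2 to compound 3 (0.22 log units; that floor lies within the scatter). For compound 3 the estimated value is 60000 nM, with an expected range from 10000 nM to 150000 nM.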

Compound 3, half-maximal inhibitory concentration: 1600 nM
Beside the measured number, compound 3's estimate is 38-fold (1.57 log units) above it; measured number below the stated range.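

In this assay, among these compounds, this position on the aromatic nitrogen gives a readable value for the first time, and the change to 3-methylphenyl is large: an at least 62-fold lower number from compound 2 to compound 3 (1.79 log units; beyond the scatter), and with methyl as the starting group, an at least 62-fold lower number from compound 1 to compound 3 (1.79 log units; beyond the scatter). Compound 2 and compound 3 hold the same atoms, joined differently, so the result on this read-out turns on how those atoms are arranged and not on which atoms are present. Both steps start from a limit, so each gives only a floor on the true size, and most of the values shown sit at that limit: the limit of > 100000 nM in this assay, at which 2 of the 3 values shown sit.

On these data alone, it remains open how much of the gain comes from the ring sitting directly on the nitrogen and how much from its methyl group. A plain phenyl or a 3-chlorophenyl at this position would separate the two.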